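A few compounds are considered here, and "the series" means these few. Any claim that something is new, unique, unknown or untested is made for them only; others in the source may bear on it.

Compound 1 `CCNc1cc(-c2ccc(NC(=O)Nc3ccc(C(F)(F)F)cc3)cc2C(F)(F)F)ccn1` is the reference point of this small set. In an assay on isolated protein for inhibition of serine/threonine-protein kinase PLK1 (Homo sapiens), read by radiometric assay and 33P incorporation, with a stated time of 40 min, tested at 20 uM, in the presence of a further agent that is not named here (on this read-out higher numbers stand for more inhibition at the one concentration tested (going by the name of the read-out) and lower numbers for less inhibition), compound 1 gives 82.9%, the highest of the three numbers recorded. Compound 2 `CCNc1cc(-c2ccc(NC(=O)Nc3ccccc3Cl)cc2C(F)(F)F)ccn1` carries a 2-chlorophenyl in place of the 4-(trifluoromethyl)phenyl on the amide-type nitrogen, and in this assay compound 2 gives 71.6%, a drop of a number 11.3 percentage points lower from compound 1 to compound 2 (beyond the scatter). Compound 3 `CCNc1cc(-c2ccc(NC(=O)Nc3ccc(C(F)(F)F)cc3)cc2OC)ccn1` has methoxy in place of trifluoromethyl on an aromatic carbon, and in this assay compound 3 gives 40.7%, a drop of a number 42.2 percentage points lower from compound 1 to compound 3 (beyond the scatter).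

Compound 4 `CCCNc1cc(-c2ccc(NC(=O)Nc3ccc(C(F)(F)F)cc3)cc2C(F)(F)F)ccn1` differs from compound 1 by methyl in place of hydrogen on a saturated chain carbon, two bonds along the chain from a nitrogen on an aromatic ring. Neither measured step bears directly on this change: both altered an aromatic substituent, whereas the change here lengthens the chain on the amine attached to the core of compound 1. The two measured steps show that compound 1 loses inhibition when its aryl substituents are altered, but they give no guide to the alkyl chain. Among the compounds with values here, with no relevant precedent, a step of no more than the usual scatter is expected in this assay. Compound 4 is therefore expected to give 80%, within 66% to 92%. The expected step is a number 2.9 percentage points lower from compound 1 to compound 4 (within the scatter).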

Compound 4, a percentage reported as inhibition, at one concentration (the size of the read-out at that concentration, not a potency): 51.3%
For compound 4 the middle estimate is 28.7 percentage points above the measured one, outside the stated range (below it).
By their numbers in this assay, from the lowest: compound 3; then compound 4; then compound 2; then compound 1.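

In this assay the chain on the amine proves to be a sensitive position: going from ethylamino to propylamino brings a number 31.6 percentage points lower from compound 1 to compound 4 (beyond the scatter), a large step for a change of 1 heavy atom that adds no hydrogen-bond donor or acceptor. The earlier compounds shown here showed only that inhibition depends on the aromatic substituents, with a large step for the methoxy of compound 3 and a modest one for the 2-chlorophenyl of compound 2, whereas compound 4 shows that the alkyl chain on the amine of compound 1 matters too. Nothing given here accounts for this loss of inhibition.

The compounds shown leave open whether the trend runs in both directions along the chain, since a methylamino group or a free amine could hold, gain or lose inhibition relative to ethylamino, and a butylamino group or a branched isopropylamino group could take it lower still or not. Going by these compounds, it also remains open whether the same lengthening would cost as much on the aromatic substituents of compound 2 or compound 3.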